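This account rests on a few compounds, and the source may have more. Where it says the series, first, only, none or still open, it means among the compounds named here.

In an ADME assay on the whole organism (Rattus norvegicus) for metabolic stability, at a dose of 1 mg/kg by the intravenous route (a lower number here means that the compound disappears faster, a higher number that the compound lasts longer), compound 1 `Cc1ccc(Cn2c(Nc3ccc(OC(C)C)c(Cl)c3)nc(=O)n(CCC(=O)O)c2=O)cc1` gives 1.6 h, while compound 2 `C[C@@H](Cn1c(=O)[nH]/c(=N\c2ccc(Oc3ccccn3)cc2)n(Cc2ccc(Cl)cc2)c1=O)C(=O)O` gives 10.1 h. Compound 2 therefore holds the higher of the two numbers, and the gap between them lies beyond the usual scatter. Compound 3 `C[C@@H](Cn1c(=O)[nH]/c(=N\c2ccc(Oc3ccnc(F)c3)cc2)n(Cc2ccc(Cl)cc2)c1=O)C(=O)O` has not yet been measured in this assay. It differs from compound 2 in one place, with 2-fluoropyridin-4-yl in place of pyridin-2-yl on an oxygen on an aromatic ring. Going by the values given here, no measured pair of compounds isolates this swap, so the expectation rests on little evidence. Among the compounds with values here, with compound 2 at 10.1 h, the higher of only two numbers, a small drop seems likelier than a rise. The expected change is a 1.3-fold lower number from compound 2 to compound 3 (0.13 log units; within the scatter), a step that would stay within the scatter. For compound 3 the estimated half-life is 7.5 h, with an expected range from 3 h to 15 h.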

Compound 3, half-life: 4.3 h
Compound 3: middle estimate off by 1.7-fold (0.24 log units), on the high side; the range from low to high includes it.
By their numbers in this assay, from the lowest: compound 1; then compound 3; then compound 2.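

In this assay, replacing pyridin-2-yl with 2-fluoropyridin-4-yl on the oxygen gives a 2.3-fold lower number from compound 2 to compound 3 (0.37 log units; beyond the scatter). Going by these compounds alone, this is the first comparison here between compounds that differ in one place, and it shows that the group on this oxygen can by itself shift the half-life beyond the scatter, while the rest of the structure stays the same. Nothing measured here explains the drop.

The swap adds a fluorine and also changes how the pyridine ring is attached to the oxygen, so this single step cannot separate the two changes. An unsubstituted pyridin-4-yl group would help to separate them, and a chlorine or a methyl group in place of the fluorine would show whether the outcome is specific to fluorine.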